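Small Swaps, Small Steps: What to Expect of Compound 4

The source may report more compounds than this note shows. Statements on the series, on what has been measured and on what is new or still open speak of the compounds shown alone.

- compound 1 `COc1ccc(C2=NOC(COc3ccc(-c4nnnn4-c4cc(OC)c(OC)c(OC)c4)cc3N)C2)cc1N` gives 3000 nM
- compound 2 `COc1ccc(C2=NOC(COc3ccc(-c4nnnn4-c4cc(OC)c(OC)c(OC)c4)cc3N)C2)cc1OC` gives 3570 nM
- compound 3 `COc1cc(C2=NOC(COc3ccc(-c4nnnn4-c4cc(OC)c(OC)c(OC)c4)cc3N)C2)ccc1O` gives 3620 nM

All three numbers come from a functional assay on MDA-MB-231 cells (Homo sapiens) for cytotoxicity, read by MTT assay, with a stated time of 48 h (on this read-out lower numbers stand for stronger inhibition and higher numbers for weaker inhibition), and lie close together. Compound 3 at 3620 nM stands level with the other two. Changes to this same group gave a 1.2-fold higher number from compound 1 to compound 3 (0.08 log units; within the scatter) and a 1.0-fold higher number from compound 2 to compound 3 (0.01 log units; within the scatter) as well as a 1.2-fold higher number from compound 1 to compound 2 (0.08 log units; within the scatter) here, so swaps at this spot have moved the number little so far. Compound 4 `COc1ccc(F)c(C2=NOC(COc3ccc(-c4nnnn4-c4cc(OC)c(OC)c(OC)c4)cc3N)C2)c1` changes it again, on a carbon with a double bond to nitrogen, with 2-fluoro-5-methoxyphenyl in place of 4-hydroxy-3-methoxyphenyl on a carbon with a double bond to nitrogen as the difference. Within the data shown here, no measured compound carries fluorine, so that part remains untested. No step beyond the scatter is therefore expected in this assay for now. The estimated step is a 1.1-fold lower number from compound 3 to compound 4 (0.03 log units; within the scatter) and nothing larger. For compound 4 the estimated value is 3400 nM within an expected range from 1500 nM to 7500 nM overall.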

Compound 4, half-maximal inhibitory concentration: 2830 nM
For compound 4 the middle estimate is 1.2-fold (0.08 log units) above the measured one; low and high end bracket the measured number.
By their numbers in this assay, from the lowest: compounds 4, 1, 2 and 3 (each within the scatter of the next).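

In this assay, 2-fluoro-5-methoxyphenyl at this position gives a 1.3-fold lower number from compound 3 to compound 4 (0.11 log units; within the scatter), a 1.3-fold lower number from compound 2 to compound 4 (0.10 log units; within the scatter) and a 1.1-fold lower number from compound 1 to compound 4 (0.03 log units; within the scatter). So a ring carrying fluorine, an atom new to this set, fits this position with no change that stands out from the scatter, whichever of the three earlier groups it replaces. Nothing available explains why these swaps matter so little. From the compounds shown here alone, all four compounds keep a substituted phenyl ring here, so it remains open whether a carboxylic acid, a morpholine ring or a longer alkyl chain in its place would move the number beyond the scatter.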